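The compounds below may be only part of what the source reports. "The series", "measured", "known", "first", "only" and "open" are said of these compounds alone.

Of the compounds shown here, three that share one core have been measured in a functional assay on FM3A cells (Mus musculus) for inhibition, read by cell counting, with a stated time of 2 days; on this read-out higher numbers stand for weaker inhibition and lower numbers for stronger inhibition. Compound 1 `C=C(Br)C(=O)Nc1cccc(-c2cn3nc(-c4ccc(F)cc4)sc3n2)c1` gives 610 nM. In this assay compound 2 `C=C(Br)C(=O)Nc1cccc(-c2cn3nc(Cc4cccc(OC)c4)sc3n2)c1` gives 1100 nM. Compound 3 `C=C(Br)C(=O)Nc1cccc(-c2cn3nc(-c4ccccc4)sc3n2)c1` gives 900 nM in this assay. The steps that link them are all small: a 1.8-fold higher number from compound 1 to compound 2 (0.26 log units; within the scatter), a 1.5-fold higher number from compound 1 to compound 3 (0.17 log units; within the scatter), and a 1.2-fold lower number from compound 2 to compound 3 (0.09 log units; within the scatter). Compound 3 thus stands among three numbers that the usual scatter does not separate; its nearest neighbour is compound 2 and its furthest is compound 1, and neither gap counts as a real difference.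

Compound 4 `C=C(Br)C(=O)Nc1cccc(-c2cn3nc(-c4cccc(OC)c4)sc3n2)c1` differs from compound 3 in one place: methoxy in place of hydrogen on an aromatic carbon. Two of the measured steps bear on this change. The step of a 1.2-fold lower number from compound 2 to compound 3 (0.09 log units; within the scatter) takes away a group that carries the same methoxy together with a linking carbon, and a 1.5-fold higher number from compound 1 to compound 3 (0.17 log units; within the scatter) swaps a fluoro on the same ring for hydrogen; both stayed within the scatter. A methoxy placed on that ring is therefore expected to give no step beyond the scatter in this assay, amounting to a 1.1-fold higher number from compound 3 to compound 4 (0.02 log units; within the scatter). Compound 4 is estimated at 950 nM, with a range from 450 nM to 2000 nM.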

Compound 4, half-maximal inhibitory concentration: 500 nM
Compound 4: the middle estimate sits 1.9-fold (0.28 log units) above what was measured; measured number inside the range.
By their numbers in this assay, from the lowest: compounds 4, 1, 3 and 2 (each within the scatter of the next, the first and the last beyond it).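

In this assay, adding the methoxy to the phenyl ring gives a 1.8-fold lower number from compound 3 to compound 4 (0.26 log units; within the scatter), which stays within the scatter, so at this place methoxy cannot be told apart from hydrogen. The clearer information concerns the linking carbon: with the methoxy present in both compounds, 3-methoxyphenyl in place of 3-methoxybenzyl gives a 2.2-fold lower number from compound 2 to compound 4 (0.34 log units; beyond the scatter), a modest step but the first among these compounds to pass beyond the scatter. Among these compounds, by contrast, a 1.2-fold lower number from compound 1 to compound 4 (0.09 log units; within the scatter) stays within the scatter, so 3-methoxyphenyl and 4-fluorophenyl are not separated here, and the only real gap in the set is the one between compound 2 and compound 4.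

The compounds shown leave open whether a hydroxyl, an amine or a carboxylic acid in place of the methoxy, or a longer chain in place of the linking carbon, would move the number further, and whether taking out the linking carbon would give a similar step on a ring without the methoxy. Among the compounds shown here, nothing else measured on these compounds offers an explanation for the one step beyond the scatter.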